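Chain length and acid versus nitrile on the aryl ether tail

This account rests on a few compounds, and the source may have more. Where it says the series, first, only, none or still open, it means among the compounds named here.

Measured compounds in an assay on isolated protein for inhibition of leukotriene B4 receptor 1 (Homo sapiens), tested at 10 uM; on this read-out lower numbers stand for less inhibition and higher numbers for more inhibition at the one concentration tested (going by the name of the read-out):
compound 1 `CCc1cc(C(C)=O)c(O)cc1OCCCCCCC#N`: 103%
compound 2 `CCc1cc(C(C)=O)c(O)cc1OCCCCCC(C)(C)C#N`: 85%
compound 3 `CCc1cc(C(C)=O)c(O)cc1OCCCC(C)(C)C(=O)O`: 89%

Compound 3 sits second of the three numbers in this assay. Against compound 2 the gap is a number 4 percentage points higher from compound 2 to compound 3 (within the scatter), which is within the scatter, so the two cannot be ordered. Against compound 1 the gap is a number 14 percentage points lower from compound 1 to compound 3 (beyond the scatter), which is beyond the scatter. The other measured step, a number 18 percentage points lower from compound 1 to compound 2 (beyond the scatter), is also beyond the scatter.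

Compound 4 `CCc1cc(C(C)=O)c(O)cc1OCCCCCC(C)(C)C(=O)O` carries the change (3-carboxy-3-methylbutyl in place of 1-carboxy-1-methylethyl on a saturated chain carbon, three bonds along the chain from an oxygen on an aromatic ring). This puts the acid on a tail of the same shape as the nitrile tail of compound 2. Within the data shown here, the steps that bear on it are the step from compound 2 to compound 3, which was within the scatter, and the step from compound 1 to compound 2, which was modest and downward. Among the measured compounds shown here, no step shows the acid on this tail directly, so the expectation is that compound 4 shows a number 4 percentage points lower from compound 3 to compound 4 (within the scatter) in this assay, with no change beyond the scatter the most likely outcome. Compound 4 is estimated at 85%, within 70% to 100%.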

Compound 4, a percentage reported as inhibition, at one concentration (the size of the read-out at that concentration, not a potency): 104%
For compound 4 the middle estimate is 19 percentage points below the measured one; the measured number lies above the stated range.
By their numbers in this assay, from the lowest: compounds 2 and 3 (each within the scatter of the next); then compounds 1 and 4 (each within the scatter of the next).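

In this assay, among these compounds, 3-carboxy-3-methylbutyl in place of 1-carboxy-1-methylethyl gives a number 15 percentage points higher from compound 3 to compound 4 (beyond the scatter), so at this place the longer acid tail reads beyond the scatter of the shorter one, which the earlier compounds did not show. Among the compounds shown here, with the tail shape held constant, carboxy in place of cyano gives a number 19 percentage points higher from compound 2 to compound 4 (beyond the scatter), the first direct comparison of acid and nitrile on one tail, and here the acid reads higher. The branched acid tail and the unbranched nitrile tail show a number 1 percentage points higher from compound 1 to compound 4 (within the scatter), so these two cannot be ordered.

Nothing available explains these steps. On these data alone, how a primary amide or a still longer chain would read at this place stays open, and this read-out gives only the size of the inhibition at one concentration.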